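A few compounds are considered here, and "the series" means these few. Any claim that something is new, unique, unknown or untested is made for them only; others in the source may bear on it.

Within the data shown here, in a functional assay on MCF7 cells (Homo sapiens) for inhibition, read by MTT assay, with a stated time of 96 h (on this read-out lower numbers stand for stronger inhibition of growth and higher numbers for weaker inhibition of growth), compound 1 (`O=C(OCc1ccccc1)SCCCCCCNC(=O)c1cc(-c2ccncc2)n[nH]1`) gives 8370 nM and is the only compound so far with an actual number. Compound 2 (`O=C(NCCCCCCS)c1cc(-c2ccc3ccccc3c2)n[nH]1`) is reported at > 50000 nM and this value is a limit of the assay, not a number.

Still unmeasured is compound 3 (`CC(=O)SCCCCCCNC(=O)c1cc(-c2ccncc2)n[nH]1`), which keeps the rest of compound 1 but carries methyl in place of benzyloxy on a carbonyl carbon whose other neighbour is sulfur (methyl in place of benzyloxy on a carbonyl carbon). The same difference, cut one bond further out, reads benzyloxycarbonyl to acetyl.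

Among the measured compounds shown here, no measured pair in this small set isolates that change, so nothing shows its size directly. The expectation therefore starts from compound 1 at 8370 nM and allows for a modest step in this assay, leaning slightly toward stronger inhibition of growth, though it may not exceed the usual scatter. The estimate expects a change a 1.7-fold lower number from compound 1 to compound 3 (0.22 log units; within the scatter) and no more than that. Compound 3 is expected to give 5000 nM within an estimated range from 1500 nM to 20000 nM once it is measured.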

Compound 3, concentration for 50% growth inhibition: 24900 nM
For compound 3 the middle estimate is 5.0-fold (0.70 log units) below the measured one; measured number outside the range, above it.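

In this assay, replacing benzyloxy with methyl on a carbonyl carbon whose other neighbour is sulfur now has a measured size: a 3.0-fold higher number from compound 1 to compound 3 (0.47 log units; beyond the scatter). This shows that the group at this place is not interchangeable, since the lower number belongs to the compound that carries benzyloxy, with its 8 heavy atoms and its six-membered aromatic ring of carbon only, and not to the one that carries methyl, with its 1 heavy atom. The change still leaves compound 3 with an actual number rather than a limit, which matters in this read-out, where one compound has only a limit: the limit of > 50000 nM in this assay, at which 1 of the 3 values shown sits.

Among these compounds, the single pair cannot tell whether the ring, the oxygen or the sheer size of benzyloxy accounts for the step, and a phenyl or an ethoxy on the same carbonyl carbon would be needed to pull these apart. Among the compounds shown here, compound 2 differs from compound 1 and compound 3 in more than one place, so no steps to it can be read, and the effect of a free thiol on the core of compound 1 stays open.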